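The source may hold more compounds than are shown below. What is called first, only, known or untested is meant among the compounds shown, and "the series" means these compounds.

In a functional assay on A549 cells (Homo sapiens) for antiproliferative activity, read by MTT assay, with a stated time of 48 h (a lower number here means a stronger inhibitor, a higher number a weaker inhibitor), compound 1 (`COc1ccccc1N1CCN(C(=O)/C=C/c2ccc(O)c(O)c2)CC1`) gives 0.98 ug/mL and compound 2 (`O=C(/C=C/c1ccc(O)c(O)c1)N1CCN(c2ccc(Cl)c(Cl)c2)CC1`) gives 1.74 ug/mL while compound 3 (`O=C(/C=C/c1ccc(O)c(O)c1)N1CCN(c2ccccn2)CC1`) gives 2.32 ug/mL on the same read-out. Compound 3 thus stands within the scatter of compound 2 (a 1.3-fold higher number from compound 2 to compound 3 (0.12 log units; within the scatter)) but beyond the scatter of compound 1 (a 2.4-fold higher number from compound 1 to compound 3 (0.37 log units; beyond the scatter)). The remaining step (a 1.8-fold higher number from compound 1 to compound 2 (0.25 log units; within the scatter)) is also within the scatter.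

Next is compound 4 (`CCN1CCN(C(=O)/C=C/c2ccc(O)c(O)c2)CC1`) with ethyl in place of pyridin-2-yl on an amine nitrogen in a ring. All three measured steps swap one ring group for another at this place, so none is a direct precedent for ethyl. They remain small, the largest being the modest step above (a 2.4-fold higher number from compound 1 to compound 3 (0.37 log units; beyond the scatter)). In this assay the expectation is therefore a step not far beyond the scatter, with only a slight lean towards a higher number. The expected change is small (a 1.3-fold higher number from compound 3 to compound 4 (0.11 log units; within the scatter)). The estimated value for compound 4 is 3 ug/mL (expected range 1.3 ug/mL to 7 ug/mL).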

Compound 4, half-maximal inhibitory concentration: 6.54 ug/mL
Compound 4: middle estimate off by 2.2-fold (0.34 log units), on the low side; measured number inside the range.
By their numbers in this assay, from the lowest: compounds 1, 2 and 3 (each within the scatter of the next, the first and the last beyond it); then compound 4.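

In this assay, among the compounds shown here, ethyl on the amine nitrogen in a ring is the only group at this place without a ring, and it gives the largest steps: a 2.8-fold higher number from compound 3 to compound 4 (0.45 log units; beyond the scatter), a 3.8-fold higher number from compound 2 to compound 4 (0.58 log units; beyond the scatter) and a 6.7-fold higher number from compound 1 to compound 4 (0.82 log units; beyond the scatter). Pyridin-2-yl, 3,4-dichlorophenyl and 2-methoxyphenyl all give lower numbers than ethyl, so among these four compounds a ring at this place goes with the lower number, and no compound goes against this. Nothing measured here explains the rise in the number with ethyl.

Ethyl differs from the other three groups both in lacking a ring and in having fewer heavy atoms, and these compounds cannot separate the two. A cyclohexyl ring and a longer chain such as hexyl at the same place would each test one of them.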